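A few compounds are considered here, and "the series" means these few. Any claim that something is new, unique, unknown or untested is made for them only; others in the source may bear on it.

In a functional assay on IMR-32 cells (Homo sapiens) for cytotoxicity (on this read-out higher numbers stand for weaker inhibition and lower numbers for stronger inhibition), compound 1 `COc1ccc(C2C(OC)C(=O)N2c2cc(OC)c(OC)c(OC)c2)cc1[N+](=O)[O-]` gives > 1000 nM; > 10000 nM (2 entries). Compound 2 `COc1ccc(C2C(OC(C)=O)C(=O)N2c2cc(OC)c(OC)c(OC)c2)cn1` stands at > 1000 nM, which is again a limit of the assay and not a number. Compound 3 `COc1ccc(C2C(O)C(=O)N2c2cc(OC)c(OC)c(OC)c2)cn1` sits at > 1000 nM, likewise a limit of the assay. Because two of the three values shown rest at that same limit (the limit of > 1000 nM in this assay, at which 2 of the 3 values shown sit), compound 2 cannot be placed against the other compounds, and the step that the two limits leave unreadable from compound 2 to compound 3 has no readable size.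

Compound 4 `COc1cc(N2C(=O)C(OC(C)=O)C2c2ccc(N)o2)cc(OC)c1OC` differs from compound 2 in one place: 5-aminofuran-2-yl in place of 6-methoxypyridin-3-yl on a saturated ring carbon. Going by the values given here, no measured step involves an exchange of one aromatic ring for another on that saturated ring carbon, and the only measured step at all is unreadable because both of its ends are limits (the limit of > 1000 nM in this assay, at which 2 of the 3 values shown sit); the repeated limits of compound 1 the several entries of compound 1 in this assay, > 1000 nM; > 10000 nM (2 entries) add no readable size either. There is therefore no ground to expect a step in this assay in either direction beyond the scatter, and the most likely outcome is that compound 4 also returns a limit. The estimate for compound 4 is 5000 nM, with a range from 800 nM to 50000 nM. That estimate amounts to an expected step that the limit leaves unreadable from compound 2 to compound 4.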

Compound 4, half-maximal inhibitory concentration: > 1000 nM
Compound 4: only a limit was reported; the forecaster's own chance of this, stated with the estimate: 80%; the middle value lies beyond the limit too.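

In this assay compound 4 gives > 1000 nM, which is a limit of the assay and not a number. Compound 2 also rests at a limit, so the ring exchange between compound 2 and compound 4 has no readable size: the limit of > 1000 nM in this assay, at which 3 of the 4 values shown sit. The compounds shown leave open how strongly each inhibits these cells, and whether 5-aminofuran-2-yl and 6-methoxypyridin-3-yl differ at all.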